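Styryl imine in place of fluorophenyl imine on compound 1

A few compounds are considered here, and "the series" means these few. Any claim that something is new, unique, unknown or untested is made for them only; others in the source may bear on it.

Three compounds of this series share one core and differ only in the aryl group on the imine carbon. Compound 1 `O=C(NNc1ccnc2cc(Cl)ccc12)c1ccccc1/N=C/c1ccc(F)cc1` gives 5.18 in a physicochemical assay for lipophilicity, measured as octanol-water partition; on this read-out lower numbers stand for lower lipophilicity and higher numbers for higher lipophilicity; compound 2 `O=C(NNc1ccnc2cc(Cl)ccc12)c1ccccc1/N=C/c1ccc(Br)cc1` gives 5.76 and compound 3 `O=C(NNc1ccnc2cc(Cl)ccc12)c1ccccc1/N=C/c1cccs1` gives 4.78. Compound 1 thus stands second highest of the three: the step of a number 0.58 log units higher from compound 1 to compound 2 (beyond the scatter), and the step of a number 0.40 log units lower from compound 1 to compound 3 (beyond the scatter). Compound 4 `O=C(NNc1ccnc2cc(Cl)ccc12)c1ccccc1/N=C/C=C/c1ccccc1` is not yet measured. It differs from compound 1 as follows: 2-phenylethenyl in place of 4-fluorophenyl on a carbon with a double bond to nitrogen. Neither measured step covers this change directly; the halogen swap from compound 1 to compound 2 and the ring swap from compound 1 to compound 3 both show that changes of this size at the imine carbon move the read-out modestly but beyond the scatter. The entering group carries one more heavy atom and no fluorine, so a modest rise is expected, with the step estimated as a number 0.32 log units higher from compound 1 to compound 4 (beyond the scatter). Compound 4 is therefore expected to give about 5.5 in this assay, within the range 5 to 6.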

Compound 4, partition coefficient: 5.54
Beside the measured number, compound 4's estimate is 0.04 log units below it, and the stated range covers the measured number.
By their numbers in this assay, from the lowest: compound 3; then compound 1; then compounds 4 and 2 (each within the scatter of the next).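

In this assay, a group with a double bond outside aromatic rings proves workable on the carbon with a double bond to nitrogen, with the change to 2-phenylethenyl giving a number 0.36 log units higher from compound 1 to compound 4 (beyond the scatter) and a number 0.76 log units higher from compound 3 to compound 4 (beyond the scatter) as its two steps beyond the scatter. The change from 4-bromophenyl gives a number 0.22 log units lower from compound 2 to compound 4 (within the scatter), so compound 4 and compound 2 cannot be told apart in this read-out, and a group without halogen thus matches the value of the bromo compound within the scatter. The data on hand offer no measurement that explains these steps. An amine or a carboxylic acid at this place, or a longer chain ending in phenyl, would test how far the read-out moves in either direction, and the compounds shown do not tell this. As far as these compounds go, whether the same steps hold on any other core also stays open.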